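Ester removal in the hydroxycyclohexanecarboxanilide series

The source may report more compounds than this note shows. Statements on the series, on what has been measured and on what is new or still open speak of the compounds shown alone.

Compound 2 `Cc1ccccc1C(=O)OC1(C(=O)Nc2ccc([N+](=O)[O-])cc2)CCCCC1` gives 352 nM in an ADME assay on WI-38 cells (Homo sapiens) for inhibition, read by MTT assay, with a stated time of 72 h (on this read-out lower numbers stand for stronger inhibition and higher numbers for weaker inhibition), the second highest of three numbers. Compound 1 `O=C(OC1(C(=O)Nc2ccc([N+](=O)[O-])cc2)CCCCC1)c1ccc(C(F)(F)F)cc1` gives 185 nM and compound 3 `O=C(OC1(C(=O)Nc2ccc([N+](=O)[O-])cc2)CCCCC1)c1ccc([N+](=O)[O-])cc1` gives 761 nM; the step of a 1.9-fold higher number from compound 1 to compound 2 (0.28 log units; within the scatter) is within the scatter, the steps of a 2.2-fold higher number from compound 2 to compound 3 (0.33 log units; beyond the scatter) and a 4.1-fold higher number from compound 1 to compound 3 (0.61 log units; beyond the scatter) are modest. Compound 4 `O=C(Nc1ccc([N+](=O)[O-])cc1)C1(O)CCCCC1` has hydrogen in place of (2-methylphenyl)carbonyl on an oxygen on a saturated carbon. Every measured step swaps one aroyl group for another; none removes the ester, so they bear on this change only loosely and show the series tolerating modest shifts. A larger loss seems plausible once the whole group is gone. Compound 4 is therefore expected to give about 2500 nM in this assay, between 500 nM and 12000 nM. The expected step is a 7.1-fold higher number from compound 2 to compound 4 (0.85 log units; beyond the scatter).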

Compound 4, half-maximal inhibitory concentration: 1220 nM
Beside the measured number, compound 4's estimate is 2.0-fold (0.31 log units) above it, and the stated range covers the measured number.
By their numbers in this assay, from the lowest: compounds 1 and 2 (each within the scatter of the next); then compounds 3 and 4 (each within the scatter of the next).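

For the compounds shown here, replacing the (2-methylphenyl)carbonyl with hydrogen on the oxygen gives a 3.5-fold higher number from compound 2 to compound 4 (0.54 log units; beyond the scatter) in this assay, the first step here that removes the aroyl group outright. The loss is only modest, and compound 4 falls within the scatter of compound 3, so the inhibition in this assay does not require the ester. Nothing available explains this step.

Still open, from the compounds shown here alone, is whether an acetyl group or a methyl ether on that oxygen would track compound 2 or compound 4. The shown compounds also cannot separate the contribution of the carbonyl from that of the aromatic ring.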